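The compounds below may be only part of what the source reports. "The series", "measured", "known", "first", "only" and "open" are said of these compounds alone.

Working notes on the exposure series. The shared core is set by compound 1 `COc1ccc2c(c1)C(=O)N(C[C@@]1(c3cc4ncccc4o3)NC(=O)N(COC(=O)C(C)(C)C)C1=O)C2`. Going by the values given here, in an ADME assay on the whole organism for pharmacokinetics, with Rattus norvegicus as the target, read by LC-MS, at a dose of 10 mg/kg by the oral route (a higher number here means more compound in the circulation at the dose given, a lower number less compound in the circulation), compound 1 gives 6640 ng.h/mL, the highest of the three numbers measured so far. Compound 2 `COc1ccc2c(c1)C(=O)N(C[C@]1(c3cc4ncccc4o3)C(=O)N(COC(=O)C(C)(C)C)C(=O)N1COC(=O)C(C)(C)C)C2` gives 1920 ng.h/mL in this assay, and compound 3 `CCOP(=O)(OCC)OCN1C(=O)N[C@@](CN2Cc3ccc(OC)cc3C2=O)(c2cc3ncccc3o2)C1=O` gives 27.9 ng.h/mL. Both measured steps start from compound 1: a 3.5-fold lower number from compound 1 to compound 2 (0.54 log units; beyond the scatter), and a 240-fold lower number from compound 1 to compound 3 (2.38 log units; beyond the scatter). Each of these changes the groups carried on the ring nitrogens of the core; neither alters the fused aromatic part.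

Compound 4 `CCN1CCN(c2ccc3oc([C@]4(CN5Cc6ccc(OC)cc6C5=O)NC(=O)N(COC(=O)C(C)(C)C)C4=O)cc3n2)CC1` keeps the whole of compound 1 except for one change: 4-ethylpiperazin-1-yl in place of hydrogen on an aromatic carbon. Among the compounds with values here, no measured step concerns a substitution on that aromatic carbon, so the two steps above serve only to show how far exposure has moved when other parts were changed, and carry over no direct expectation. Absent direct precedent, the working assumption is a modest change at most. In this assay compound 4 is expected to give 3500 ng.h/mL, with a range from 700 ng.h/mL to 15000 ng.h/mL. That estimate corresponds to the expected step of a 1.9-fold lower number from compound 1 to compound 4 (0.28 log units; within the scatter).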

Compound 4, area under the concentration-time curve: 433 ng.h/mL
Estimate against measurement, compound 4: 8.1-fold (0.91 log units) above; the whole stated range lies above it.
By their numbers in this assay, from the lowest: compound 3; then compound 4; then compound 2; then compound 1.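

In this assay, going by these compounds alone, the aromatic carbon next to the ring nitrogen proves sensitive to substitution: 4-ethylpiperazin-1-yl in place of hydrogen gives a 15-fold lower number from compound 1 to compound 4 (1.19 log units; beyond the scatter), the first measured step at this position. The earlier steps shown here changed only the groups on the ring nitrogens of the core, whereas here those groups stay as in compound 1 and exposure still moves beyond the scatter, so the aromatic part of the series also bears on this read-out. Nothing available here bears on why the number falls with this change.

From the compounds shown here alone, it remains open whether a morpholine or a single methyl group on the same carbon would give a step of similar size. Also open is whether the step from 4-ethylpiperazin-1-yl depends on the group carried on the ring nitrogen, since it is shown with only one such group.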